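The compounds below may be only part of what the source reports. "The series", "measured", "known", "first", "only" and "open" are said of these compounds alone.

Measured in a functional assay on RPMI-8226 cells (Homo sapiens) for cytotoxicity, read by sulforhodamine B assay, with a stated time of 48 h; a higher number here means a weaker inhibitor of growth, a lower number a stronger inhibitor of growth:
compound 1 `ClCc1ccc(Cn2cnc3c(Cl)ncnc32)cc1`: 9340 nM
compound 2 `ClCc1cccc(Cn2cnc3ncnc(Cl)c32)c1`: 34700 nM
compound 3 `ClCc1cccc(Cn2cnc3c(Cl)ncnc32)c1`: 16200 nM

Compound 2 stands highest of the three numbers in this assay; compound 3 sits nearest, below it by a gap beyond the scatter, and compound 1 lies furthest below, also beyond the scatter. Compound 4 `ClCc1cccc(Cn2cnc3nc(Cl)nc(Cl)c32)c1` differs from compound 2 by chloro in place of hydrogen on an aromatic carbon, a chloro in place of hydrogen on an aromatic carbon, between two ring nitrogen atoms. Within the data shown here, no pair of measured compounds shares this change, so nothing measured tells its size or direction. A small downward step is expected in this assay for compound 4, though one within the scatter would not surprise. The expected step is a 1.4-fold lower number from compound 2 to compound 4 (0.14 log units; within the scatter). Compound 4 is expected at 25000 nM, within a range from 8000 nM to 70000 nM.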

Compound 4, concentration for total growth inhibition: 4160 nM
Compound 4: middle estimate off by 6.0-fold (0.78 log units), on the high side; the measured number lies below the stated range.
By their numbers in this assay, from the lowest: compound 4; then compounds 1 and 3 (each within the scatter of the next); then compound 2.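

In this assay chloro in place of hydrogen on an aromatic carbon, between two ring nitrogen atoms, gives an 8.3-fold lower number from compound 2 to compound 4 (0.92 log units; beyond the scatter) and so moves the series towards stronger growth inhibition. This position therefore accepts a chloro, and the change has a real effect on the number, though that reading rests on this single pair. Nothing available bears on the reason for the step. On these data alone, whether an amine or a methoxy group at this position would move the number the same way remains open. Also open, as far as these compounds go, is whether the same chloro would have a similar effect on compound 1 or compound 3.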